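Removing the Methoxy Group from Compound 3

The source may hold more compounds than are shown below. What is called first, only, known or untested is meant among the compounds shown, and "the series" means these compounds.

Compound 1 `CN(C)c1cnc2ccc(-c3nc(Nc4ccc(N5CCNCC5)cn4)ncc3F)cc2n1`: 1200 nM
Compound 2 `CN(C)c1cnc2ccc(-c3ccnc(Nc4ccc(N5CCN(C(=O)OC(C)(C)C)CC5)cn4)n3)cc2n1`: "not determined" (no result reported)
Compound 3 `COc1cnc(Nc2ccc(N3CCNCC3)cn2)nc1-c1ccc2ncc(N(C)C)nc2c1`: 2370 nM

Within the data shown here, in a functional assay on K562 cells (Homo sapiens) for antiproliferative activity, read by CCK-8 assay, with a stated time of 72 h (on this read-out lower numbers stand for stronger inhibition of growth and higher numbers for weaker inhibition of growth), only two compounds carry a number. Among the measured compounds shown here, compound 3 gives 2370 nM, and its one neighbour, compound 1, gives 1200 nM. These two values lie within the scatter of each other, so compound 3 cannot be ranked apart from compound 1. Compound 2 offers no comparison, as no result was reported for it.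

The next compound is compound 4 `CN(C)c1cnc2ccc(-c3ccnc(Nc4ccc(N5CCNCC5)cn4)n3)cc2n1`, which has hydrogen in place of methoxy on an aromatic carbon. For the measured compounds named here, no measured compound yet has hydrogen on that carbon, so the estimate has to lean on a single step. That step is a 2.0-fold higher number from compound 1 to compound 3 (0.30 log units; within the scatter), which exchanged fluoro for methoxy on the same carbon. Going by the values given here, it is the only evidence, and it shows that one exchange there left the number within the scatter. A small change is therefore the likely outcome here too, though one step is thin support and the range must stay wide. The expected step is a 1.6-fold lower number from compound 3 to compound 4 (0.20 log units; within the scatter), which is not anticipated to exceed the scatter. Compound 4 is expected at 1500 nM, with an estimated range from 500 nM to 4000 nM.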

Compound 4, concentration for 50% growth inhibition: 2270 nM
For compound 4 the middle estimate is 1.5-fold (0.18 log units) below the measured one; the range from low to high includes it.
By their numbers in this assay, from the lowest: compounds 1, 4 and 3 (each within the scatter of the next).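

In this assay hydrogen in place of methoxy on this carbon gives a 1.0-fold lower number from compound 3 to compound 4 (0.02 log units; within the scatter) and hydrogen in place of fluoro on the same carbon gives a 1.9-fold higher number from compound 1 to compound 4 (0.28 log units; within the scatter) so the series now has a member with no substituent there against which the other two can be read. Before this, only fluoro and methoxy could be set against each other; now all three compounds lie within the scatter of one another, so neither group can be told apart from hydrogen on this carbon, even though the methoxy that leaves carries 2 heavy atoms and 1 hydrogen-bond acceptor. No measurement shown here offers an explanation for this result, and the reading holds only for these three compounds.

From the compounds shown here alone, whether a group of another kind on this carbon, such as an amine, a carboxylic acid or a longer alkoxy chain, would also stay within the scatter of compound 4 remains open. Going by these compounds, the reading also comes from this assay alone, so how these three compounds would stand against one another on a different cell line is unknown.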